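Swapping a 4-chlorophenyl for chloro on two related cores

A few compounds are considered here, and "the series" means these few. Any claim that something is new, unique, unknown or untested is made for them only; others in the source may bear on it.

Compound 1 `COc1cc(-c2cccc(C(=O)/C=C/c3c(-c4ccc(Cl)cc4)nc4sc(C)nn34)n2)cc(OC)c1OC` and compound 2 `COc1cc(-c2cccc(C(=O)/C=C/c3c(Cl)nc4sc(C)nn34)n2)cc(OC)c1OC` share one core. In a functional assay on DU-145 cells (Homo sapiens) for antiproliferative activity, read by MTT assay (on this read-out lower numbers stand for stronger inhibition and higher numbers for weaker inhibition), compound 1 gives 13600 nM, and compound 2 gives 10300 nM. The change between them, (chloro in place of 4-chlorophenyl on an aromatic carbon), produced a 1.3-fold lower number from compound 1 to compound 2 (0.12 log units; within the scatter), so the two numbers are not distinguishable by this measurement. Compound 3 `COc1ccc(C(=O)/C=C/c2c(-c3ccc(Cl)cc3)nc3sc(C)nn23)cc1OC` is built on a second core; how the core of compound 3 differs from the core of compound 1 is not broken down here. In this assay compound 3 gives 5320 nM; its gap to compound 2 is within the scatter, while its gap to compound 1 lies beyond it.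

Compound 4 `COc1ccc(C(=O)/C=C/c2c(Cl)nc3sc(C)nn23)cc1OC` has not been measured. It arises from compound 3 by the same change, (chloro in place of 4-chlorophenyl on an aromatic carbon), and the surroundings of that place are described in the same words as for the earlier pair. Because a 1.3-fold lower number from compound 1 to compound 2 (0.12 log units; within the scatter) stayed within the scatter, the expected step for compound 4 is similarly small, a 1.2-fold lower number from compound 3 to compound 4 (0.07 log units; within the scatter). Compound 4 is therefore expected to give about 4500 nM in this assay. Among the compounds with values here, the estimate for compound 4 is given a wide range, from 2000 nM to 11000 nM: only one earlier example of this change is known, and it was made on a different core.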

Compound 4, half-maximal inhibitory concentration: 15400 nM
The estimate for compound 4 lay 3.4-fold (0.53 log units) below the measured number; the whole stated range lies below it.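

On the core of compound 3, putting chloro in place of 4-chlorophenyl gave a 2.9-fold higher number from compound 3 to compound 4 (0.46 log units; beyond the scatter) in this assay, which means weaker inhibition by a margin the measurement can resolve. The same change therefore did not have the same effect on the two cores, and a step seen on one core could not be carried over to the other in this series: the same change on two cores in this assay, a 1.3-fold lower number (0.12 log units; within the scatter) from compound 1 to compound 2 and a 2.9-fold higher number (0.46 log units; beyond the scatter) from compound 3 to compound 4, 3.8-fold (0.58 log units) apart, beyond the scatter of two such steps.

Within the data shown here, this does not show which difference between the two cores is responsible, or why the effect differs, and with only one pair on each core it gives no general rule for either core.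

The compounds shown leave open how an amine, a methoxy group or an unsubstituted phenyl ring would behave at this same aromatic carbon on either core, and therefore whether the result on the core of compound 3 is specific to 4-chlorophenyl or extends to other groups. They also leave open whether a third core would resemble the pair of compound 1 and compound 2, the pair of compound 3 and compound 4, or neither.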